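This account rests on a few compounds, and the source may have more. Where it says the series, first, only, none or still open, it means among the compounds named here.

Measured so far:
- compound 1, `CNc1nc(-c2ccccc2)nc2c1nnn2Cc1ccccc1Cl`: 191000000 nM
- compound 2, `OC1CCC(Nc2nc(-c3ccccc3)nc3c2nnn3Cc2ccccc2Cl)CC1`: 3100000 nM

In an assay on isolated protein for binding affinity to adenosine receptor A1 (Bos taurus) (on this read-out lower numbers stand for stronger inhibition and higher numbers for weaker inhibition), compound 2 holds the lowest of the two numbers; its nearest neighbour is compound 1, and the step of a 62-fold lower number from compound 1 to compound 2 (1.79 log units; beyond the scatter) separates them. For the measured compounds named here, that is the only measured step, and it shows that replacing methyl on the ring nitrogen with a larger ring-bearing group lowered the number strongly.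

Compound 3, `Clc1ccccc1Cn1nnc2c(NC3CC3)nc(-c3ccccc3)nc21`, differs from compound 2 in one place: cyclopropyl in place of 4-hydroxycyclohexyl on a nitrogen on an aromatic ring. The incoming group is smaller than the one that leaves and lacks its hydroxyl, so it sits between compound 1 and compound 2 in what is known. Going by the values given here, no step covering cyclopropyl on this nitrogen has been measured; the direction relative to compound 2 is therefore uncertain.

The estimate for compound 3 in this assay is 5000000 nM, with a range from 500000 nM to 50000000 nM. This corresponds to an expected step of a 1.6-fold higher number from compound 2 to compound 3 (0.21 log units; within the scatter), a modest weakening that may not exceed the scatter.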

Compound 3, inhibition constant: 11000000 nM
The estimate for compound 3 lay 2.2-fold (0.34 log units) below the measured number; low and high end bracket the measured number.
By their numbers in this assay, from the lowest: compound 2; then compound 3; then compound 1.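

In this assay, a 17-fold lower number from compound 1 to compound 3 (1.24 log units; beyond the scatter) shows that a small carbon ring on this nitrogen already gives a large drop without any hydroxyl, so the drop seen with compound 2 does not depend on that hydroxyl alone. The other step, a 3.5-fold higher number from compound 2 to compound 3 (0.55 log units; beyond the scatter), shows that going from cyclopropyl to the larger, hydroxyl-bearing 4-hydroxycyclohexyl still adds to that drop, though by less. Across the three compounds, the number falls in the order methyl, cyclopropyl, 4-hydroxycyclohexyl, and none of them goes against that order.

The remaining gap between compound 2 and compound 3 combines ring size and the hydroxyl, and a plain cyclohexyl on this nitrogen would be needed to separate the two. No measurement at hand explains this order.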